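Biphenyl Extension of an Acetamidine Hydrazide Acid

The source may hold more compounds than are shown below. What is called first, only, known or untested is meant among the compounds shown, and "the series" means these compounds.

Measured so far:
compound 1 `N=C(N)Nc1cccc(C(=O)NNC(=O)CC(CC(=O)O)c2ccccc2)c1` — 1.13
compound 2 `CC(=N)Nc1cccc(C(=O)NNC(=O)CC(CC(=O)O)c2ccccc2)c1` — 1.44

In a physicochemical assay for lipophilicity (on this read-out higher numbers stand for higher lipophilicity and lower numbers for lower lipophilicity), compound 2 stands highest of the two numbers, with compound 1 nearest and lower, a gap shown by a number 0.31 log units higher from compound 1 to compound 2 (beyond the scatter). Compound 3 `CC(=N)Nc1cccc(C(=O)NNC(=O)CC(CC(=O)O)c2ccc(-c3ccccc3)cc2)c1` differs from compound 2 by phenyl in place of hydrogen on an aromatic carbon. For the measured compounds named here, no measured step covers such a change; the only step known, amino to methyl, does not bear on it. The expectation therefore rests on the change itself, and a clear rise is expected, given by a number 1.66 log units higher from compound 2 to compound 3 (beyond the scatter). Compound 3 is estimated at 3.1, within a range from 2.3 to 3.9.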

Compound 3, partition coefficient: 3.11
Compound 3: middle estimate off by 0.01 log units, on the low side; the range from low to high includes it.
By their numbers in this assay, from the lowest: compound 1; then compound 2; then compound 3.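

In this assay, phenyl on this aromatic carbon, para to a large group, gives a number 1.67 log units higher from compound 2 to compound 3 (beyond the scatter) and counts as a large step. The earlier change, at another place in the molecule, was only modest at a number 0.31 log units higher from compound 1 to compound 2 (beyond the scatter). So this carbon is a place where one added ring moves the read-out far more than that swap of methyl for amino did.

Compounds 2 and 3 show only hydrogen and phenyl here. As far as these compounds go, how a chlorine, a methoxy group or a pyridine ring at the same carbon would compare stays open. Nothing shown here explains the size of this step.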